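One methyl added to a thiophen-2-yl sulfonyl compound

This account rests on a few compounds, and the source may have more. Where it says the series, first, only, none or still open, it means among the compounds named here.

In a functional assay on HepG2 cells (Homo sapiens) for inhibition, read by sulforhodamine B assay, with a stated time of 74 h (a lower number here means a stronger inhibitor, a higher number a weaker inhibitor), compound 1 `O=C1C=CC2(C=C1)OCC(=O)N2S(=O)(=O)c1ccccc1` gives > 10000 nM, which is a limit and not a number. Compound 3 `O=C1C=CC2(C=C1)OCC(=O)N2S(=O)(=O)c1cccs1` gives > 10000 nM, also a limit, and so stands at the limit of > 10000 nM in this assay, at which 2 of the 3 values shown sit. Going by the values given here, the one measured step that bears on it, a step that the two limits leave unreadable from compound 1 to compound 3, puts thiophen-2-yl in place of phenyl on a sulfonyl sulfur, and it has no readable size. Compound 2 `Cc1ccc(S(=O)(=O)N2C(=O)C(C)OC23C=CC(=O)C=C3)cc1` gives 540 nM, a real number. Compound 2 also carries a methyl on a saturated ring carbon, but its group on the sulfonyl sulfur is different as well, so it offers only an indirect hint.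

Compound 4 `CC1OC2(C=CC(=O)C=C2)N(S(=O)(=O)c2cccs2)C1=O` differs from compound 3 by a single change, methyl in place of hydrogen on a saturated ring carbon. Compound 2, at 540 nM, is the only reason to expect a move towards stronger inhibition in this assay, and this rests on one compound. Compound 4 may yet return only a limit. The expected change is an at least 8.3-fold lower number from compound 3 to compound 4 (0.92 log units; beyond the scatter). For compound 4 the estimate is 1200 nM, with an expected range from 250 nM to 10000 nM.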

Compound 4, half-maximal inhibitory concentration: > 10000 nM
Compound 4 was reported as a limit; the forecaster's own chance of this, stated with the estimate: 25%; middle value at least 8.3-fold (0.92 log units) from the limit.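

Going by these compounds alone, with the methyl on the saturated ring carbon present in both compounds, putting thiophen-2-yl in place of 4-methylphenyl on the sulfonyl sulfur in this assay gives an at least 18-fold higher number from compound 2 to compound 4 (1.26 log units; beyond the scatter), the first readable step in this small set and a large one. The methyl alone is therefore not enough to give a measurable value on the thiophen-2-yl compound, and the group on the sulfonyl sulfur clearly matters when this methyl is present. The steps from compound 1 to compound 3 and from compound 3 to compound 4 cannot be read, because both ends of each are limits and not numbers: the limit of > 10000 nM in this assay, at which 3 of the 4 values shown sit.

Any effect of the methyl on the thiophen-2-yl compound could still be hidden behind that limit, and how much of the strength of compound 2 depends on the methyl also remains open. It is also unknown whether a longer chain such as ethyl, or an amine, on the same saturated ring carbon would bring a thiophen-2-yl compound to a measurable value.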